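From Propyl to Isobutyl on a Selenocyanate Carbamate

This account rests on a few compounds, and the source may have more. Where it says the series, first, only, none or still open, it means among the compounds named here.

Compound 1 `CCCOC(=O)Nc1ccc([Se]C#N)cc1` was tested in a functional assay on HT-29 cells (Homo sapiens) for cytotoxicity, read by MTT assay, with a stated time of 72 h (a higher number here means a weaker inhibitor of growth, a lower number a stronger inhibitor of growth), and gave 28400 nM. Of the three numbers recorded so far this is the highest, yet all three sit within the usual scatter of one another: compound 3 `CCCCOC(=O)Nc1ccc([Se][Se]c2ccc(NC(=O)OCCCC)cc2)cc1` gives 27600 nM, and compound 2 `O=C(Nc1ccc([Se][Se]c2ccc(NC(=O)OCc3ccc([N+](=O)[O-])cc3)cc2)cc1)OCc1ccc([N+](=O)[O-])cc1` gives 16700 nM, so no ranking among them can be claimed. Compound 4 `CC(C)COC(=O)Nc1ccc([Se]C#N)cc1` has not yet been measured in this assay. It differs from compound 1 by methyl in place of hydrogen on a saturated chain carbon bound to two saturated chain carbons. Within the data shown here, no measured pair shows a step of this kind, so the data give no guide to its size. Compound 4 is expected to give 25000 nM, within 10000 nM and 60000 nM. The expected step of a 1.1-fold lower number from compound 1 to compound 4 (0.06 log units; within the scatter) is small and would stay within the scatter.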

Compound 4, concentration for 50% growth inhibition: 8100 nM
Compound 4: middle estimate off by 3.1-fold (0.49 log units), on the high side, outside the stated range (below it).
By their numbers in this assay, from the lowest: compound 4; then compounds 2, 3 and 1 (each within the scatter of the next).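

In this assay the change from propyl to isobutyl gives a 3.5-fold lower number from compound 1 to compound 4 (0.54 log units; beyond the scatter) for one added methyl on a saturated chain carbon bound to two saturated chain carbons. Among these compounds, this shows that the number responds to a small change in the carbamate's alkyl group, which the earlier compounds could not show. Nothing at hand explains the size of this step. The compounds shown leave open whether a straight butyl chain on the same selenocyanate carbamate would match isobutyl, and whether a tert-butyl or cyclohexyl group would extend the step.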